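Para-substituent swap on the aryl ring of the shared core

This account rests on a few compounds, and the source may have more. Where it says the series, first, only, none or still open, it means among the compounds named here.

Measured so far:
compound 1 `CCCCc1ccc(-c2cc(=O)c3c(o2)C(CC)(CC)C(=O)C(CC)=C3O)cc1` — 111 uM
compound 2 `CCOc1ccc(-c2cc(=O)c3c(o2)C(CC)(CC)C(=O)C(CC)=C3O)cc1` — > 52.4 uM

In a functional assay on KB cells (Homo sapiens) for antiproliferative activity, read by sulforhodamine B assay, with a stated time of 3 days (a lower number here means that less compound is needed, a higher number that more compound is needed for the effect), compound 1 gives 111 uM. For compound 2 this assay reports only a limit, > 52.4 uM, so compound 2 is known to be weak but not by how much. The step that the limit leaves unreadable from compound 1 to compound 2 therefore cannot be sized, since the limit of > 52.4 uM in this assay, at which 1 of the 2 values shown sits, hides one end of it.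

Compound 3 `CCC1=C(O)c2c(oc(-c3ccc(F)cc3)cc2=O)C(CC)(CC)C1=O` carries fluoro in place of ethoxy on an aromatic carbon. No measured step bears directly on this change; both measured compounds sit at weak potency, which gives no reason to expect a large move in this assay. Compound 3 is expected at 80 uM, range 30 uM to 200 uM. The step that the limit leaves unreadable from compound 2 to compound 3 is an estimate only.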

Compound 3, concentration for half-maximal effect: 33 uM
Estimate against measurement, compound 3: 2.4-fold (0.38 log units) above; low and high end bracket the measured number.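

Fluoro at this position gives the first step that can be sized in this assay: a 3.4-fold lower number from compound 1 to compound 3 (0.53 log units; beyond the scatter). The position therefore responds to the group it carries, though only modestly so far. The comparison with ethoxy is looser, an at least 1.5-fold lower number from compound 2 to compound 3 (0.20 log units; that floor lies within the scatter), and rests on a limit for compound 2: the limit of > 52.4 uM in this assay, at which 1 of the 3 values shown sits.

The compounds shown leave open how an amine or a carboxylic acid on this aromatic carbon would read in this assay. Going by these compounds, the step from compound 1 to compound 2 cannot be read, so the order of butyl and ethoxy remains unknown.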